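The compounds below may be only part of what the source reports. "The series", "measured", "known", "first", "only" and "open" are said of these compounds alone.

Measured so far in an in vitro ADME assay on microsomes from liver (Homo sapiens) for metabolic stability, tested at 5 uM; on this read-out lower numbers stand for a shorter-lived compound and higher numbers for a longer-lived compound:
compound 1 `CC(C)CCn1nc(-c2cccs2)c(O)c(C2=NS(=O)(=O)c3cc(CCC(N)=O)ccc3N2)c1=O`: > 1 h (a limit of the assay)
compound 2 `CC(C)CCn1nc(-c2cccs2)c(O)c(C2=NS(=O)(=O)c3cc(NC(=O)C4CC4)ccc3N2)c1=O`: 0.0833 h

Among the compounds with values here, compound 2 gives 0.0833 h in this assay, the only actual number in this pair. Compound 1 gives > 1 h, which is a limit of the assay and not a number.

The next compound is compound 3 `CC(C)CCn1nc(-c2cccs2)c(O)c(C2=NS(=O)(=O)c3cc(C#N)ccc3N2)c1=O`, which has cyano in place of (cyclopropylcarbonyl)amino on an aromatic carbon. Within the data shown here, the one measured step that bears on this change is an at least 12-fold lower number from compound 1 to compound 2 (1.07 log units; beyond the scatter). It concerns the same aromatic carbon and is large, beyond the scatter, and its size rests on (the limit of > 1 h in this assay, at which 1 of the 2 values shown sits). Among the measured compounds shown here, no measured compound carries cyano, so this single step gives the direction and only a rough size. Removing (cyclopropylcarbonyl)amino is expected to give a longer-lived compound, with a large step upward rather than none. The expected change is a 7.2-fold higher number from compound 2 to compound 3 (0.86 log units; beyond the scatter). For compound 3 the estimate is 0.6 h, with an expected range from 0.15 h to 2 h.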

Compound 3, half-life: 0.16 h
For compound 3 the middle estimate is 3.8-fold (0.57 log units) above the measured one; measured number inside the range.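

In this assay, cyano in place of (cyclopropylcarbonyl)amino gives a 1.9-fold higher number from compound 2 to compound 3 (0.28 log units; within the scatter), so this read-out does not separate the two groups, even though cyano carries no ring and no hydrogen-bond donor. With 2-carbamoylethyl as the reference, cyano gives an at least 6.2-fold lower number from compound 1 to compound 3 (0.79 log units; beyond the scatter), so among the three groups shown at this aromatic carbon only 2-carbamoylethyl stands apart, while the other two remain together at the short-lived end. Compound 1 gives > 1 h, which is a limit of the assay and not a number, so the sizes of the steps involving compound 1 are bounds only: the limit of > 1 h in this assay, at which 1 of the 3 values shown sits.

Still open, going by these compounds, is whether the result for compound 1 follows the carbamoyl end of 2-carbamoylethyl or the chain that carries it; a carboxylic acid on the same chain, or a plain alkyl chain at this aromatic carbon, would separate the two. Only this one position varies among the compounds shown, so it is also open whether the same ranking of groups would hold with a different group in place of the thiophene or the chain on the rest of the shared core.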